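Trimming a basic side chain: the expected shift in lipophilicity

A few compounds are considered here, and "the series" means these few. Any claim that something is new, unique, unknown or untested is made for them only; others in the source may bear on it.

Of the compounds shown here, three sharing one core have been measured in a physicochemical assay for lipophilicity; on this read-out lower numbers stand for lower lipophilicity and higher numbers for higher lipophilicity. Compound 1 `Cc1csc2cc([C@H](C)Nc3ncnc(N)c3C#N)c(-c3cccc(CN4CCC(CN(C)Cc5ccccn5)CC4)c3)c(=O)n12` gives 2, the second highest of the three numbers. Compound 2 `Cc1csc2cc([C@H](C)Nc3ncnc(N)c3C#N)c(Cc3cccc(CN(C)CC(C)C)c3)c(=O)n12` gives 2.3, which lies within the scatter of compound 1, so no order between the two can be read. Compound 3 `Cc1csc2cc([C@H](C)Nc3ncnc(N)c3C#N)c(Cc3cccc(CN)c3)c(=O)n12` gives -0.3, well below compound 1.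

Compound 4 `Cc1csc2cc([C@H](C)Nc3ncnc(N)c3C#N)c(-c3cccc(CN4CCC(N(C)C)CC4)c3)c(=O)n12` has not yet been measured. It differs from compound 1 in one place: dimethylamino in place of (methyl((pyridin-2-yl)methyl)amino)methyl on a saturated ring carbon.

Among the measured compounds shown here, only one measured step bears on this change: a number 2.60 log units lower from compound 2 to compound 3 (beyond the scatter). There a large part of an amine-bearing side chain was removed and the number fell sharply. The step from compound 1 to compound 4 also removes a sizeable part of a side chain, though a tertiary amine remains, so a smaller drop seems reasonable.

Compound 4 is therefore expected to give 1.3, ranging from 0.5 to 2.1, which means an estimated a number 0.70 log units lower from compound 1 to compound 4 (beyond the scatter).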

Compound 4, distribution coefficient: 0.5
The estimate for compound 4 lay 0.80 log units above the measured number; measured number inside the range.
By their numbers in this assay, from the lowest: compound 3; then compound 4; then compounds 1 and 2 (each within the scatter of the next).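

Putting dimethylamino in place of (methyl((pyridin-2-yl)methyl)amino)methyl on the saturated ring carbon gives, in this assay, a number 1.50 log units lower from compound 1 to compound 4 (beyond the scatter). Among the compounds shown here, the only earlier step was at a different place, on a saturated chain carbon bound to an aromatic carbon, whereas this one shows that a large step also occurs on the saturated ring carbon, even with an amine group still attached there. No measurement shown accounts for the size of this step.

The change removes the aromatic ring and the rest of the group at once, and the compounds shown do not separate the two. Going by these compounds, how a methylamino group, a hydroxyl group or a longer dialkylamino chain on this same ring carbon would read in this assay remains open.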